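Removing a Methoxy Group from a Quinoline-Bearing Core

A few compounds are considered here, and "the series" means these few. Any claim that something is new, unique, unknown or untested is made for them only; others in the source may bear on it.

Measured compounds:
compound 1, `COc1ccc2nccc([C@@H](O)[C@@H]3CC4CCN3CC4c3cn([C@H]4C[C@H](n5cc(C)c(=O)[nH]c5=O)O[C@@H]4CO)nn3)c2c1`, 1.3 ug/mL;
compound 2, `Cc1cn([C@H]2C[C@H](n3cc(C4CN5CCC4C[C@H]5[C@H](O)c4ccnc5ccccc45)nn3)[C@@H](CO)O2)c(=O)[nH]c1=O`, 11.6 ug/mL;
compound 3, `C=CC1CN2CCC1C[C@H]2[C@H](OCc1cn([C@H]2C[C@H](n3cc(C)c(=O)[nH]c3=O)O[C@@H]2CO)nn1)c1ccnc2ccc(OC)cc12`, 2.1 ug/mL.

All three were tested in a functional assay on KB cells (Homo sapiens) for inhibition; a higher number here means that more compound is needed for the effect, a lower number that less compound is needed. Compound 1 and compound 2 share one core and differ in a single place: hydrogen in place of methoxy on an aromatic carbon. That change gave an 8.9-fold higher number from compound 1 to compound 2 (0.95 log units; beyond the scatter), so the compound without the methoxy group needed more material for the same effect. Compound 3 has a different core from compound 1; how the two cores differ is not broken down here.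

Compound 4, `C=CC1CN2CCC1C[C@H]2[C@H](OCc1cn([C@H]2C[C@H](n3cc(C)c(=O)[nH]c3=O)O[C@@H]2CO)nn1)c1ccnc2ccccc12`, has not yet been measured. It stands to compound 3 as compound 2 stands to compound 1, with the same change in the same place: hydrogen in place of methoxy on an aromatic carbon. For the measured compounds named here, only one earlier example of this change exists here, so the expectation rests on it alone. In this assay a step of about a 6.7-fold higher number from compound 3 to compound 4 (0.82 log units; beyond the scatter) is expected, because compound 2 showed an 8.9-fold higher number from compound 1 to compound 2 (0.95 log units; beyond the scatter). The estimate for compound 4 is therefore 14 ug/mL, with a likely range from 5 ug/mL to 40 ug/mL.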

Compound 4, concentration for half-maximal effect: > 100 ug/mL
Compound 4: no number, only a limit (the forecaster's own chance of this, stated with the estimate: 5%); middle value at least 7.1-fold (0.85 log units) away from the limit.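

In this assay compound 4 gives > 100 ug/mL, which is a limit of the assay and not a number. Putting hydrogen in place of methoxy gives an at least 47-fold higher number from compound 3 to compound 4 (1.67 log units; beyond the scatter), so the direction of the change carries over from one core to the other, but its size does not: the same change on two cores in this assay, an 8.9-fold higher number (0.95 log units; beyond the scatter) from compound 1 to compound 2 and an at least 47-fold higher number (1.67 log units; beyond the scatter) from compound 3 to compound 4, at least 5.3-fold (0.72 log units) apart, beyond the scatter of two such steps The full size of the new step remains unknown, and two pairs of compounds neither explain the gap between the cores nor give a rule for other cores: the limit of > 100 ug/mL in this assay, at which 1 of the 4 values shown sits.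

The compounds shown leave open whether other groups on the same aromatic carbon, such as hydroxyl, fluorine or ethoxy, would keep the lower numbers seen with methoxy. Which feature of the core of compound 3 makes its step differ from the one on the core of compound 1 also stays open.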